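Methyl for methoxy on the amide ring of compound 1

The source may report more compounds than this note shows. Statements on the series, on what has been measured and on what is new or still open speak of the compounds shown alone.

Measured compounds:
compound 1 `COc1ccccc1C(=O)NCc1ccc(CNS(=O)(=O)c2cccc3ccccc23)cc1` in an assay on MDA-MB-231 cells for displacement of a labelled ligand from C-X-C chemokine receptor type 4 (Homo sapiens), read by fluorescence and microscopy, with stated times of 10 min and 30 min (a lower number here means that less compound is needed, a higher number that more compound is needed for the effect), gives > 1000 nM
compound 2 `COc1ccccc1C(=O)NCc1ccc(CNS(=O)(=O)c2ccc(Cl)cc2)cc1` in this assay gives 1000 nM

Compound 1 stands at a limit in this assay: its result of > 1000 nM is a limit of the assay and not a number. Among the measured compounds shown here, only one step has been measured: a number no higher from compound 1 to compound 2 (the limit leaves the size open), where the naphthalen-1-yl on the sulfonyl sulfur gives way to 4-chlorophenyl. Its size cannot be read because of the limit of > 1000 nM in this assay, at which 1 of the 2 values shown sits.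

Compound 3 `Cc1ccccc1C(=O)NCc1ccc(CNS(=O)(=O)c2cccc3ccccc23)cc1` keeps the naphthalen-1-yl sulfonamide of compound 1 and changes the other end: methyl in place of methoxy on an aromatic carbon. For the measured compounds named here, no measured step touches the methoxy, so the one step available, from the sulfonyl side, does not bear on this change. The account therefore rests on where compound 1 stands, and compound 3 is expected to stay near the weak end of this assay, with a step that the limit leaves unreadable from compound 1 to compound 3 that is not expected to reach beyond the scatter. For compound 3 in this assay the estimate is 1500 nM, with a range from 500 nM to 5000 nM.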

Compound 3, effective concentration (reported as EC, without a stated level of effect): 100 nM
Beside the measured number, compound 3's estimate is 15-fold (1.18 log units) above it; measured number below the stated range.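

In this assay, the change from 2-methoxyphenyl to 2-methylphenyl gives an at least 10-fold lower number from compound 1 to compound 3 (1.00 log units; beyond the scatter), which shows that this end of the molecule, untouched by the earlier step, can shift the result well beyond the scatter. The earlier step, on the sulfonyl side, could have suggested that the naphthalen-1-yl group was what held compound 1 back, yet compound 3 keeps that group and gives 100 nM, so the group is compatible with a far lower number once methyl stands on the other ring. Only a lower bound on the size of this step can be read, and its true size stays open because compound 1 stands at a limit: the limit of > 1000 nM in this assay, at which 1 of the 3 values shown sits.

On these data alone, what a bare hydrogen, a chlorine atom or an ethyl group would give at this place on the ring remains open, so it cannot be said whether methyl itself is favourable or methoxy is simply unfavourable. Also open, as far as these compounds go, is whether the same change would carry over to the 4-chlorophenyl sulfonamide of compound 2, which appears here only with methoxy.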